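From 3-Chlorophenyl to 4-Chlorophenyl on an Amide Nitrogen

A few compounds are considered here, and "the series" means these few. Any claim that something is new, unique, unknown or untested is made for them only; others in the source may bear on it.

Three closely related compounds share one core and differ only in the group on the amide-type nitrogen: compound 1 (`O=C(CCCCC(CCSC(=O)c1ccccc1)SC(=O)c1ccccc1)Nc1ccccc1Cl`), compound 2 (`O=C(CCCCC(CCSC(=O)c1ccccc1)SC(=O)c1ccccc1)Nc1cccc(Cl)c1`) and compound 3 (`O=C(CCCCC(CCSC(=O)c1ccccc1)SC(=O)c1ccccc1)Nc1ccc(Cl)cc1`). In a functional assay on Bel-7402 cells (Homo sapiens) for inhibition, read by MTT assay, with a stated time of 24 h, tested at 1 ug/mL (on this read-out higher numbers stand for more inhibition of growth at the one concentration tested and lower numbers for less inhibition of growth), compound 1 gives 7.37%. In this assay compound 2 is reported as "not active" (no number reported), so it has no single number and cannot be given an exact place on the scale.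

The next step leads from compound 2 to compound 3: 4-chlorophenyl in place of 3-chlorophenyl on an amide-type nitrogen. In plain terms, 4-chlorophenyl stands in place of 3-chlorophenyl on an amide-type nitrogen, and the two compounds have the same atoms, joined differently. Among the compounds with values here, no measured pair here shows the effect of this change alone, so the forecast is cautious. No step beyond the usual scatter is expected in this assay, because compound 1 reaches only 7.37% and compound 2 is recorded as "not active" (no number reported). A report of no activity for the new compound would also be unsurprising.

For compound 3 the expected growth inhibition is 5%, with an estimated range of 0% to 15%.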

Compound 3, percent growth inhibition at one concentration: 9.62%
The estimate for compound 3 lay 4.6 percentage points below the measured number; the range from low to high includes it.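

In this assay compound 3 gives 9.62%, while the entry for compound 2 reads "not active" (no number reported), so the step from compound 2 to compound 3 cannot be read as a size. Within the data shown here, the one step that can be read concerns 4-chlorophenyl in place of 2-chlorophenyl on the amide-type nitrogen: a number 2.3 percentage points higher from compound 1 to compound 3 (within the scatter), which means that these two chlorophenyl groups cannot be told apart at this single concentration. No measurement at hand offers an explanation for these results.

What the compounds shown leave open is whether a different group on the phenyl ring, such as a methoxy group, a nitrile or a carboxylic acid, would give a step beyond the usual scatter, and whether a longer chain on the amide-type nitrogen would do so. A single concentration also leaves open how the growth inhibition of these compounds would change at other concentrations, so a full dose-response curve for compound 1 and compound 3 remains an open question.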